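Swapping the chlorophenyl arm of compound 3 for furan

This account rests on a few compounds, and the source may have more. Where it says the series, first, only, none or still open, it means among the compounds named here.

Of the compounds shown here, three have been measured in a functional assay on the whole organism (strain albino) for inhibition, with Rattus norvegicus as the target, read by paw edema, with stated times of 30 min and 2 h, at a dose of 100 mg/kg by the oral route; a lower number here means less inhibition, a higher number more inhibition at the dose given (going by the name of the read-out). Compound 1 `O=C(CO[N+](=O)[O-])Nc1ccc(C(=O)/C=C/c2ccco2)cc1` gives 36%, compound 2 `CC(=O)c1ccc(OCC(=O)Nc2ccc(C(=O)/C=C/c3ccc(Cl)cc3)cc2)cc1` gives 52%, and compound 3 `C/C(=N/O)c1ccc(OCC(=O)Nc2ccc(C(=O)/C=C/c3ccc(Cl)cc3)cc2)cc1` gives 54%. Compound 3 thus holds the highest of the three numbers, but its nearest neighbour, compound 2, lies within the scatter, so the two cannot be ordered; only compound 1 sits clearly lower. Among the measured compounds shown here, the single one-place step, a number 2 percentage points higher from compound 2 to compound 3 (within the scatter), shows that changing the group on the aromatic carbon of the phenoxy end left the read-out essentially unchanged.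

Compound 4 `C/C(=N/O)c1ccc(OCC(=O)Nc2ccc(C(=O)/C=C/c3ccco3)cc2)cc1` arises from compound 3 by the change (furan-2-yl in place of 4-chlorophenyl on a double-bonded chain carbon bound to a double-bonded chain carbon). For the measured compounds named here, no measured step covers this exchange. Compound 1, which already carries the furan-2-yl group, differs from compound 2 in more than one place, so its lower value can only be taken as a hint. On that hint, compound 4 is expected to come out below compound 3, with the expected step being a number 12 percentage points lower from compound 3 to compound 4 (beyond the scatter). The estimate for compound 4 is 42%, in a range from 30% to 55%.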

Compound 4, a percentage reported as inhibition, in the whole organism at one dose (the size of the read-out at that dose, not a potency): 44%
For compound 4 the middle estimate is 2 percentage points below the measured one, and the stated range covers the measured number.
By their numbers in this assay, from the lowest: compounds 1, 4, 2 and 3 (each within the scatter of the next, the first and the last beyond it).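

In this assay, among the compounds shown here, furan-2-yl in place of 4-chlorophenyl on a double-bonded chain carbon bound to a double-bonded chain carbon gives a number 10 percentage points lower from compound 3 to compound 4 (within the scatter), the first direct reading of this exchange, and it does not separate the two rings. With the furan-2-yl arm held the same, the group of 10 heavy atoms in place of the group of 3 heavy atoms, on an oxygen on a saturated carbon, gives a number 8 percentage points higher from compound 1 to compound 4 (within the scatter), so neither single change lies beyond the scatter. Nothing available explains these numbers.

What the compounds shown leave open is whether a plain phenyl or a thiophene ring on the same chain carbon would give a clearly different read-out. Also open, as far as these compounds go, is whether an amine or a carboxylic acid on the phenoxy end would do so.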